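Anilide Swap on a Sulfonamide Core: Expecting Another Limit

A few compounds are considered here, and "the series" means these few. Any claim that something is new, unique, unknown or untested is made for them only; others in the source may bear on it.

compound 1 `COc1ccc(NC(=O)CN(c2cc(Cl)ccc2OC)S(=O)(=O)c2ccccc2)cc1OC`: > 20000 nM
compound 2 `COc1ccc(Cl)cc1N(CC(=O)N1CCc2ccccc21)S(=O)(=O)c1ccccc1`: > 20000 nM

In a functional assay on SH-SY5Y cells (Homo sapiens), read by MTT assay, with a stated time of 24 h (a lower number here means that less compound is needed, a higher number that more compound is needed for the effect), compound 1 gives > 20000 nM, which is a limit of the assay rather than a number. In this assay compound 2 gives > 20000 nM, also a limit. The step that the two limits leave unreadable from compound 1 to compound 2 cannot be sized because of the limit of > 20000 nM in this assay, at which 2 of the 2 values shown sit. Compound 2 therefore stands at the limit with no measured value placing it. Compound 3 `COc1ccc(Cl)cc1N(CC(=O)Nc1ccc(C(F)(F)F)cc1)S(=O)(=O)c1ccccc1` differs from compound 2 by (4-(trifluoromethyl)phenyl)amino in place of 2,3-dihydro-1H-indol-1-yl on a carbonyl carbon. For the measured compounds named here, no measured step bears on this change, so no direction in this assay is expected. Compound 3 is estimated at 30000 nM, between 8000 nM and 120000 nM. The expected step is a step that the limit leaves unreadable from compound 2 to compound 3, most likely reported as a limit again.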

Compound 3, half-maximal effective concentration: 3750 nM
Compound 3: middle estimate off by 8.0-fold (0.90 log units), on the high side; measured number outside the range, below it.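

In this assay, the group on the carbonyl carbon can decide whether a measurable number appears at all: (4-(trifluoromethyl)phenyl)amino in place of 2,3-dihydro-1H-indol-1-yl gives an at least 5.3-fold lower number from compound 2 to compound 3 (0.72 log units; beyond the scatter). On the amide-type nitrogen, 4-(trifluoromethyl)phenyl in place of 3,4-dimethoxyphenyl gives an at least 5.3-fold lower number from compound 1 to compound 3 (0.72 log units; beyond the scatter). The full size of both steps stays unknown because each starts from a limit: the limit of > 20000 nM in this assay, at which 2 of the 3 values shown sit.

From the compounds shown here alone, whether the trifluoromethyl group is needed remains open. A plain phenyl or a pyridine ring on that amide-type nitrogen would test this.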